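The source may hold more compounds than are shown below. What is called first, only, known or untested is meant among the compounds shown, and "the series" means these compounds.

Measured compounds in a functional assay on Fem-X cells (Homo sapiens) for cytotoxicity, read by MTT assay, with a stated time of 72 h; a lower number here means a stronger inhibitor, a higher number a weaker inhibitor:
- compound 1 `COc1ccc(Nc2cccnc2)cc1`: 118000 nM
- compound 2 `Cc1ccc(-c2ccnc(Nc3ccc(F)cc3)c2)cc1`: 79000 nM
- compound 3 `COc1ccc(Nc2cc(-c3ccc(C)cc3)ccn2)cc1`: 33000 nM

Compound 3 stands lowest of the three numbers in this assay; its nearest neighbour is compound 2, and the step of a 2.4-fold lower number from compound 2 to compound 3 (0.38 log units; beyond the scatter) marks the gain from methoxy in place of fluoro on an aromatic carbon. Among the measured compounds shown here, compound 1 sits furthest from compound 3 and is the only measured compound that carries no aryl group on the core.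

Compound 4 `COc1ccc(Nc2ccccn2)cc1` is not yet measured. Its change from compound 3 is hydrogen in place of 4-methylphenyl on an aromatic carbon, on an aromatic carbon of the six-membered aromatic ring with 1 nitrogen, opposite the ring nitrogen. For the measured compounds named here, no single measured step removes the 4-methylphenyl, so the only guide is the pair of values of compound 1 and compound 3: the compound without the aryl group gives the higher number in this assay. On that basis a weakening step a 3.6-fold higher number from compound 3 to compound 4 (0.56 log units; beyond the scatter) is expected, and compound 4 is estimated at 120000 nM, between 50000 nM and 300000 nM.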

Compound 4, half-maximal inhibitory concentration: 123000 nM
Estimate against measurement, compound 4: 1.0-fold (0.01 log units) below; measured number inside the range.
By their numbers in this assay, from the lowest: compound 3; then compounds 2, 1 and 4 (each within the scatter of the next).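

In this assay, among the compounds shown here, removing the 4-methylphenyl from the aromatic carbon opposite the ring nitrogen gives a 3.7-fold higher number from compound 3 to compound 4 (0.57 log units; beyond the scatter), the first reading of this group in which nothing else in the structure changes. The step is modest but beyond the scatter, so at this position the 4-methylphenyl is tied to the lower number of compound 3, and without it compound 4 lies within the scatter of compound 1 at 118000 nM. Nothing available explains this step.

The compounds shown leave open whether the aromatic ring or its methyl carries the step, and whether a plain phenyl, a morpholine or a carboxylic acid on this carbon would keep the number of compound 3. They also leave open whether the same step appears with fluoro in place of methoxy.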